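Chloro for hydrogen on the shared core of compound 3

The compounds below may be only part of what the source reports. "The series", "measured", "known", "first", "only" and "open" are said of these compounds alone.

Series notes. Compound 1 `Nc1nc(Cl)c2ncn(Cc3ccc(CCl)cc3)c2n1` is the weakest point measured: in a functional assay on SK-MEL-28 cells (Homo sapiens) for cytotoxicity, read by sulforhodamine B assay, with a stated time of 48 h (a lower number here means a stronger inhibitor of growth, a higher number a weaker inhibitor of growth), compound 1 gives 18200 nM. Compound 2 `ClCc1ccccc1Cn1cnc2c(Cl)nc(Cl)nc21` carries two chloro groups on the shared core, and in this assay compound 2 gives 1230 nM. Among the measured compounds shown here, these two differ in more than one place, so their values say only that the doubly chlorinated member sits at a lower number than the amino-bearing one.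

Compound 3 `ClCc1ccc(Cn2cnc3ncnc(Cl)c32)cc1` is reported in this assay as "not determined" (no result reported) and so has no number there; its position in the series is open, and the step to compound 4 therefore rests on compound 2 alone.

Compound 4 `ClCc1ccc(Cn2cnc3nc(Cl)nc(Cl)c32)cc1` differs from compound 3 by chloro in place of hydrogen on an aromatic carbon. For the measured compounds named here, compound 4 carries the same two chloro groups on the shared core as compound 2, so the step from compound 3 to compound 4 in this assay is expected to run toward a lower number, of moderate size, but with no measured pair of this kind the size is uncertain and could fall within the scatter.

Compound 4 is estimated at 2000 nM, with a range from 500 nM to 8000 nM, anchored on compound 2 at 1230 nM.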

Compound 4, concentration for 50% growth inhibition: 2180 nM
Beside the measured number, compound 4's estimate is 1.1-fold (0.04 log units) below it; low and high end bracket the measured number.
By their numbers in this assay, from the lowest: compounds 2 and 4 (each within the scatter of the next); then compound 1.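

In this assay, among the compounds shown here, compound 4 gives 2180 nM but compound 3 has no number, so no step from compound 3 to compound 4 can be read. The compounds shown leave open how chloro in place of hydrogen on the shared core shifts growth inhibition. No supporting data bear on this result.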